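Swapping the dichlorophenyl ketone for a methoxyphenyl ketone

The source may report more compounds than this note shows. Statements on the series, on what has been measured and on what is new or still open speak of the compounds shown alone.

Measured so far:
compound 1, `COc1ccc(-c2cc(/C=C/C(=O)c3ccc(N)cc3)[nH]n2)cc1`: 1000 nM
compound 2, `COc1cc(-c2cc(/C=C/C(=O)c3ccc(Cl)c(Cl)c3)[nH]n2)cc(OC)c1OC`: 4290 nM

In a functional assay on HCT-15 cells (Homo sapiens) for inhibition, read by sulforhodamine B assay, with a stated time of 48 h (a higher number here means a weaker inhibitor of growth, a lower number a stronger inhibitor of growth), compound 2 gives the higher of the two numbers; compound 1 gives a lower one, and the gap between them lies beyond the scatter. Compound 3, `COc1ccc(C(=O)/C=C/c2cc(-c3cc(OC)c(OC)c(OC)c3)n[nH]2)cc1`, has not been measured. It differs from compound 2 in one place: 4-methoxyphenyl in place of 3,4-dichlorophenyl on a carbonyl carbon. Going by the values given here, no measured pair shows this change, so the step of a 1.5-fold lower number from compound 2 to compound 3 (0.19 log units; within the scatter) is only an expectation, and a small lowering that may stay within the scatter seems most likely. Compound 3 is expected to give about 2800 nM in this assay, somewhere between 900 nM and 9000 nM.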

Compound 3, concentration for 50% growth inhibition: 1580 nM
Compound 3: middle estimate off by 1.8-fold (0.25 log units), on the high side, within the range that was stated.
By their numbers in this assay, from the lowest: compounds 1 and 3 (each within the scatter of the next); then compound 2.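

In this assay the group on the carbonyl carbon clearly matters: 4-methoxyphenyl in place of 3,4-dichlorophenyl gives a 2.7-fold lower number from compound 2 to compound 3 (0.43 log units; beyond the scatter) with the rest of the molecule unchanged. Going by these compounds alone, this is the first single-place comparison, and it shows that growth inhibition responds to a change at this position. No measurement here explains the step. Going by these compounds, whether removing the chlorines or adding the methoxy matters more stays open, and so does how a nitrile or a carboxylic acid on this ring would behave.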